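Moving a hydroxyl from one hydroxyphenyl position to another

The source may hold more compounds than are shown below. What is called first, only, known or untested is meant among the compounds shown, and "the series" means these compounds.

Three compounds share one core, each carrying two hydroxyphenyl groups and a five-membered ring. Compound 1 `Oc1ccc(-c2cc(-c3cccs3)cc(-c3cccc(O)c3)n2)cc1` gives 780 nM in a functional assay on T47D cells (Homo sapiens) for cytotoxicity, read by CCK-8 assay; on this read-out higher numbers stand for weaker inhibition and lower numbers for stronger inhibition. Compound 2 `Oc1cccc(-c2cc(-c3ccoc3)cc(-c3ccccc3O)n2)c1` reaches only the assay limit of > 50000 nM in this assay. Compound 3 `Oc1ccc(-c2cc(-c3ccoc3)cc(-c3ccccc3O)n2)cc1` likewise stands at the limit of > 50000 nM in this assay, so its true value is not known. Going by the values given here, the one measured step, a step that the two limits leave unreadable from compound 2 to compound 3, cannot be read because both ends are limits, and the limit of > 50000 nM in this assay, at which 2 of the 3 values shown sit, marks where two of the three values sit.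

Compound 4 `Oc1ccc(-c2cc(-c3ccoc3)cc(-c3cccc(O)c3)n2)cc1` differs from compound 3 by 3-hydroxyphenyl in place of 2-hydroxyphenyl on an aromatic carbon. Among the compounds with values here, no measured step follows the same change, so the evidence is indirect: compound 1, which also carries a 3-hydroxyphenyl group together with a 4-hydroxyphenyl group, gives a measurable value, whereas the two compounds bearing a 2-hydroxyphenyl group do not. Compound 4 is therefore expected to move into the measurable range, with an estimated 6000 nM between 1000 nM and 40000 nM. The expected step of an at least 8.3-fold lower number from compound 3 to compound 4 (0.92 log units; beyond the scatter) is toward stronger inhibition, though its size stays uncertain.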

Compound 4, half-maximal inhibitory concentration: 2610 nM
For compound 4 the middle estimate is 2.3-fold (0.36 log units) above the measured one; low and high end bracket the measured number.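

In this assay, the position of the hydroxyl on the group next to the ring nitrogen matters greatly: 3-hydroxyphenyl in place of 2-hydroxyphenyl gives an at least 19-fold lower number from compound 3 to compound 4 (1.28 log units; beyond the scatter), and 4-hydroxyphenyl in place of 2-hydroxyphenyl gives an at least 19-fold lower number from compound 2 to compound 4 (1.28 log units; beyond the scatter). The step between compound 2 and compound 3 still cannot be read, and compound 2 and compound 3 both remain at a limit: the limit of > 50000 nM in this assay, at which 2 of the 4 values shown sit. The five-membered ring counts for less, since furan-3-yl in place of thiophen-2-yl gives a 3.3-fold higher number from compound 1 to compound 4 (0.52 log units; beyond the scatter), and inhibition stays measurable with either ring.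

Open, on these data alone, is whether an amine or a methoxy group could stand in for the hydroxyl at this position. Also open, as far as these compounds go, is whether 2-hydroxyphenyl would give the same loss alongside thiophen-2-yl, and why the hydroxyl position has so large an effect.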